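The source may report more compounds than this note shows. Statements on the series, on what has been measured and on what is new or still open speak of the compounds shown alone.

Measured compounds:
compound 1 `N#CC1=C(NCC(=O)N2CCOCC2)N(c2ccccc2)C(=O)N2CCCCC(N3CCCC3)C12` — 43.9%
compound 2 `CCOC(=O)C(=O)NC1=C(C#N)C2C(N3CCCC3)CCCCN2C(=O)N1c1ccccc1` — 71.2%
compound 3 `N#CC1=C(/N=C/c2ccc([N+](=O)[O-])cc2)N(c2ccccc2)C(=O)N2CCCCC(N3CCCC3)C12` — 66%

In a functional assay on the whole organism (strain albino) for inhibition, with Rattus norvegicus as the target, read by paw edema, with a stated time of 1 h, at a dose of 20 mmol/kg by the intraperitoneal route (on this read-out higher numbers stand for more inhibition at the one dose given (going by the name of the read-out) and lower numbers for less inhibition), compound 3 stands second highest of the three. Its nearest neighbour is compound 2, with a number 5.2 percentage points lower from compound 2 to compound 3 (within the scatter), while compound 1 lies furthest away, with a number 22.1 percentage points higher from compound 1 to compound 3 (beyond the scatter). The unmeasured compound 4 `N#CC1=C(NCC(=O)N2CCCCC2)N(c2ccccc2)C(=O)N2CCCCC(N3CCCC3)C12` is reached from compound 3 by the change (a group of 10 heavy atoms (7 carbon, 2 nitrogen, 1 oxygen; one six-membered non-aromatic ring with 1 hetero atom) in place of a group of 11 heavy atoms (7 carbon, 2 nitrogen, 2 oxygen; one six-membered aromatic ring of carbon only), on a double-bonded ring carbon). Among the measured compounds shown here, the step that bears on this is the one between compound 1 and compound 3, a number 22.1 percentage points higher from compound 1 to compound 3 (beyond the scatter). For the measured compounds named here, compound 4 carries a (((piperidin-1-yl)carbonyl)methyl)amino group where compound 1 carries a ((morpholin-4-yl)carbonyl)methyl group on the same amine nitrogen; the two differ in no other place, and no step for that pair has been measured. Reversing the step from compound 1 to compound 3 therefore points to a modest fall, and compound 4 is expected to land near compound 1, an estimated step of a number 20 percentage points lower from compound 3 to compound 4 (beyond the scatter). Compound 4 is estimated at 46%, in the range 30% to 64%.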

Compound 4, a percentage reported as inhibition, in the whole organism at one dose (the size of the read-out at that dose, not a potency): 38%
The estimate for compound 4 lay 8 percentage points above the measured number, within the range that was stated.
By their numbers in this assay, from the lowest: compounds 4 and 1 (each within the scatter of the next); then compounds 3 and 2 (each within the scatter of the next).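

In this assay, the piperidin-1-yl and morpholin-4-yl amides cannot be told apart, with a number 5.9 percentage points lower from compound 1 to compound 4 (within the scatter), so at this carbonyl carbon the exchange of one six-membered ring for the other leaves the result within the scatter. The larger steps, a number 28 percentage points lower from compound 3 to compound 4 (beyond the scatter) and a number 33.2 percentage points lower from compound 2 to compound 4 (beyond the scatter), show that a second ((ring)carbonyl)methyl group on the amine nitrogen also sits beyond the scatter from both other compounds, so among these four compounds the two bearing such a group form the lower pair. Nothing available explains these steps. On these data alone, whether an open-chain amine such as diethylamino or a piperazin-1-yl ring on the same carbonyl carbon would fall with this lower pair remains open. So does whether a carboxylic acid in place of the ethyl ester of compound 2 would keep its place in the upper pair.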